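Tolerability of Two Cores Under a Shared Aromatic Exchange

This account rests on a few compounds, and the source may have more. Where it says the series, first, only, none or still open, it means among the compounds named here.

Compound 1 `CC(=O)c1ccc2c(c1)nc(-c1ccoc1)n2C1CCCCC1` and compound 2 `CC(=O)c1ccc2c(c1)nc(-c1ccccn1)n2C1CCCCC1` share a core and differ only in one aromatic substituent. In an ADME assay on BHK-21 cells (Mesocricetus auratus) for cytotoxicity, read by MTT assay (a lower number here means that less compound is tolerated, a higher number that more compound is tolerated), compound 1 gives 77000 nM. Compound 2 reaches a limit of this assay, >= 100000 nM, and is reported only as that limit. The step of an at least 1.2-fold higher number from compound 1 to compound 2 (0.11 log units; that floor lies within the scatter) follows the change (pyridin-2-yl in place of furan-3-yl on an aromatic carbon), and its size rests on (the limit of >= 100000 nM in this assay, at which 1 of the 3 values shown sits).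

Compound 3 `C/C(=N\NC(N)=O)c1ccc2c(c1)nc(-c1ccoc1)n2C1CCCCC1` carries a different core from compound 1; the difference between the two cores is a group of 7 heavy atoms (3 carbon, 3 nitrogen, 1 oxygen; no ring) in place of a group of 3 heavy atoms (2 carbon, 1 oxygen; no ring), on an aromatic carbon. In this assay compound 3 is recorded as "not determined" (no result reported), so no number stands for it.

Compound 4 `C/C(=N\NC(N)=O)c1ccc2c(c1)nc(-c1ccccn1)n2C1CCCCC1`, not yet measured, is related to compound 3 by pyridin-2-yl in place of furan-3-yl on an aromatic carbon. The place of the change is described in the same words as for the step from compound 1 to compound 2, so the change is the same kind of change made on the other core.

For the measured compounds named here, for compound 4 in this assay a value near the same limit is expected, since the only measured instance of this change, an at least 1.2-fold higher number from compound 1 to compound 2 (0.11 log units; that floor lies within the scatter), ran toward that limit. The estimate for compound 4 is 100000 nM, expected to lie between 55000 nM and 200000 nM, with a fair chance that only a limit is reported.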

Compound 4, half-maximal cytotoxic concentration: > 100000 nM
Compound 4: only a limit was reported; the forecaster's own chance of this, stated with the estimate: 65%; the middle value lies on the limit itself.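

In this assay compound 4 is reported only as a limit, > 100000 nM. Compound 2 is also reported only as a limit, >= 100000 nM, and no number stands for compound 3, so no new step can be read from compound 2 to compound 4 or from compound 3 to compound 4. The compounds shown leave open how much compound 2 and compound 4 are actually tolerated, and whether they differ at all.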